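Swapping Chloro for Fluoro Beside a Diethylamino Group

The source may hold more compounds than are shown below. What is called first, only, known or untested is meant among the compounds shown, and "the series" means these compounds.

Compound 1 `CC(C)(C)Nc1c(C#N)c(F)c2c(N)nc(N)nc2c1Cl` gives 313 ug/mL in a functional assay on A549 cells (Homo sapiens) for cytotoxicity, read by MTT assay; a higher number here means a weaker inhibitor, a lower number a stronger inhibitor. Compound 2 `CC(C)(C)Nc1c(C#N)c(F)c2c(N)nc(N)nc2c1F` reaches only the limit of > 1000 ug/mL in this assay, so no number is known for it. Compound 3 `CCN(CC)c1c(C#N)c(F)c2c(N)nc(N)nc2c1Cl` gives 7.1 ug/mL in this assay.

Compound 2 differs from compound 1 by fluoro in place of chloro on an aromatic carbon, and the step was an at least 3.1-fold higher number from compound 1 to compound 2 (0.50 log units; beyond the scatter), running into (the limit of > 1000 ug/mL in this assay, at which 1 of the 3 values shown sits). Compound 3 differs from compound 1 by diethylamino in place of (tert-butyl)amino on an aromatic carbon, with the step of a 44-fold lower number from compound 1 to compound 3 (1.64 log units; beyond the scatter).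

Compound 4 `CCN(CC)c1c(C#N)c(F)c2c(N)nc(N)nc2c1F` differs from compound 3 by fluoro in place of chloro on an aromatic carbon. The surroundings differ from the earlier swap only in being ortho to a diethylamino group rather than ortho to a (tert-butyl)amino group, so this is the same kind of change. The expected step is a 3.5-fold higher number from compound 3 to compound 4 (0.55 log units; beyond the scatter), resting on the earlier step of an at least 3.1-fold higher number from compound 1 to compound 2 (0.50 log units; beyond the scatter) from compound 1 to compound 2, whose true size is hidden by the limit. Compound 4 is therefore estimated at 25 ug/mL in this assay, plausibly between 8 ug/mL and 120 ug/mL.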

Compound 4, half-maximal inhibitory concentration: 26.5 ug/mL
The estimate for compound 4 lay 1.1-fold (0.03 log units) below the measured number; measured number inside the range.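

In this assay, fluoro in place of chloro on an aromatic carbon gave a 3.7-fold higher number from compound 3 to compound 4 (0.57 log units; beyond the scatter), and the earlier swap points the same way: the same change on two cores in this assay, an at least 3.1-fold higher number (0.50 log units; beyond the scatter) from compound 1 to compound 2 and a 3.7-fold higher number (0.57 log units; beyond the scatter) from compound 3 to compound 4; the limit leaves it open whether they differ. Diethylamino in place of (tert-butyl)amino gave an at least 37-fold lower number from compound 2 to compound 4 (1.57 log units; beyond the scatter), and this also points the same way as its earlier counterpart: the same change on two cores in this assay, a 44-fold lower number (1.64 log units; beyond the scatter) from compound 1 to compound 3 and an at least 37-fold lower number (1.57 log units; beyond the scatter) from compound 2 to compound 4; the limit leaves it open whether they differ. Compound 2 gives > 1000 ug/mL, which is a limit of the assay and not a number, so these pairs show that each change kept its direction on two cores but not that its size carried over.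

The compounds shown leave open whether bromo or methoxy in place of the chloro would follow the same course. They also leave open whether a smaller amine such as dimethylamino, or a ring amine such as piperidine, would behave like diethylamino.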